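Swapping a pentylamino chain for a fused saturated bicycle

This account rests on a few compounds, and the source may have more. Where it says the series, first, only, none or still open, it means among the compounds named here.

Compound 1 `CCCCCNc1ncnc2c1ncn2[C@@H]1O[C@H](COS(N)(=O)=O)[C@@H](O)[C@H]1O` carries a pentylamino group on its aromatic core. In a functional assay on K562 cells (Homo sapiens) for antiproliferative activity, read by CellTiter-Glo, with a stated time of 72 h (a lower number here means that less compound is needed, a higher number that more compound is needed for the effect), compound 1 gives 181 nM. Compound 2 `CCCCCCNc1ncnc2c1ncn2[C@@H]1O[C@H](COS(N)(=O)=O)[C@@H](O)[C@H]1O` gives 160 nM in this assay, and the step of a 1.1-fold lower number from compound 1 to compound 2 (0.05 log units; within the scatter) shows that the longer chain changes little. Compound 3 `NS(=O)(=O)OC[C@H]1O[C@@H](n2cnc3c(NCC4CCCO4)ncnc32)[C@H](O)[C@@H]1O` is reported only as a limit of > 1000 nM in this assay. Its step of an at least 5.5-fold higher number from compound 1 to compound 3 (0.74 log units; beyond the scatter) shows that a ring in place of the chain costs potency. Compound 4 `NS(=O)(=O)OC[C@H]1O[C@@H](n2cnc3c(N4CCC5CCCCC5C4)ncnc32)[C@H](O)[C@@H]1O` changes (a group of 10 heavy atoms (9 carbon, 1 nitrogen; one six-membered non-aromatic ring of carbon only, one six-membered non-aromatic ring with 1 hetero atom) in place of a group of 6 heavy atoms (5 carbon, 1 nitrogen; no ring), on an aromatic carbon). A weaker result is expected for compound 4 because an at least 5.5-fold higher number from compound 1 to compound 3 (0.74 log units; beyond the scatter) already shows a ring at this place losing potency, and the expected step is a 5.0-fold higher number from compound 1 to compound 4 (0.70 log units; beyond the scatter). Compound 4 is therefore estimated at 900 nM, within a range from 250 nM to 3500 nM.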

Compound 4, half-maximal effective concentration: > 1000 nM
Compound 4 was reported as a limit; the forecaster's own chance of this, stated with the estimate: 40%; middle value at least 1.1-fold (0.04 log units) from the limit.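

Compound 4 is reported only as a limit, and compound 3 stands at the same one: the limit of > 1000 nM in this assay, at which 2 of the 4 values shown sit. The fused group, which has no hydrogen-bond donor where pentylamino has one, gives an at least 5.5-fold higher number from compound 1 to compound 4 (0.74 log units; beyond the scatter) and an at least 6.2-fold higher number from compound 2 to compound 4 (0.79 log units; beyond the scatter) in this assay, so a second, larger ring-bearing group also falls behind both open chains. The step between compound 3 and compound 4 cannot be read from two limits.

As far as these compounds go, it stays open whether any ring at this place can match the chains. A cyclohexylamino group or a single piperidine ring could test this, and an octylamino chain would show how far lengthening the chain remains harmless.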